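Pyridin-2-ylmethyl amide in the piperazine series

This account rests on a few compounds, and the source may have more. Where it says the series, first, only, none or still open, it means among the compounds named here.

Compound 1 `CCN(C(C)=O)C(C)c1ccccc1N1CCN(C(=O)[C@H](CC(=O)N2CCC2)Cc2ccc(Cl)cc2)CC1` gives 340 nM in a functional assay with Melanocortin receptor 4 (Homo sapiens) as the target, read by cAMP accumulation; a higher number here means that more compound is needed for the effect, a lower number that less compound is needed. For the measured compounds named here, compound 2 `CCN(C(C)=O)C(C)c1ccccc1N1CCN(C(=O)[C@H](CC(=O)NCc2ccccc2F)Cc2ccc(Cl)cc2)CC1` gives 89 nM in this assay, the lowest of the two numbers so far; the only step measured, a 3.8-fold lower number from compound 1 to compound 2 (0.58 log units; beyond the scatter), replaces azetidin-1-yl by (2-fluorobenzyl)amino on a carbonyl carbon. Compound 3 `CCN(C(C)=O)C(C)c1ccccc1N1CCN(C(=O)[C@H](CC(=O)NCc2ccccn2)Cc2ccc(Cl)cc2)CC1` is not yet measured; its change from compound 2 is pyridin-2-yl in place of 2-fluorophenyl on a saturated chain carbon bound to an amide-type nitrogen. Going by the values given here, no measured step bears on this change: the one step available concerns the amine side of the carbonyl, not the aromatic ring carried by the benzylic carbon, so no direction can be drawn from it. The expected step of a 1.7-fold higher number from compound 2 to compound 3 (0.23 log units; within the scatter) is therefore small, within or only slightly beyond the scatter, with a wide range. Compound 3 is estimated at 150 nM, with a range from 50 nM to 500 nM.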

Compound 3, half-maximal effective concentration: 37 nM
For compound 3 the middle estimate is 4.1-fold (0.61 log units) above the measured one, and the stated range ends above it.
By their numbers in this assay, from the lowest: compound 3; then compound 2; then compound 1.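

On the saturated chain carbon bound to an amide-type nitrogen, pyridin-2-yl in place of 2-fluorophenyl gives a 2.4-fold lower number from compound 2 to compound 3 (0.38 log units; beyond the scatter) in this assay, so the aromatic ring carried by this chain affects the read-out, which the earlier step on the amine side could not show. Against the azetidin-1-yl amide, ((pyridin-2-yl)methyl)amino gives a 9.2-fold lower number from compound 1 to compound 3 (0.96 log units; beyond the scatter), the largest step among the three compounds. Nothing available accounts for either step.

The compounds shown leave open whether the step from compound 2 to compound 3 follows from the loss of the fluorine or the entry of the ring nitrogen, which plain phenyl on the same carbon would separate. Also open, as far as these compounds go, are the effects of pyridin-3-yl, pyridin-4-yl and a longer chain before the ring.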